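A chloro substituent on the urea phenyl of compound 1

The source may report more compounds than this note shows. Statements on the series, on what has been measured and on what is new or still open speak of the compounds shown alone.

Compound 1, `CC1(C)CC(NC(=O)Nc2ccccc2)c2cc(Cl)ccc2O1`: in a functional assay on U-373MG ATCC cells (Homo sapiens) for inhibition, read by MTT assay, with a stated time of 72 h (on this read-out higher numbers stand for weaker inhibition and lower numbers for stronger inhibition), compound 1 gives 68000 nM.
Compound 2, `CC1(C)CC(NC(=S)NCc2ccccc2)c2cc(Br)ccc2O1`: in this assay compound 2 gives 29000 nM.

Of the two numbers measured in this assay, compound 1 holds the higher one, and its gap to compound 2 lies beyond the scatter. Compound 3, `CC1(C)CC(NC(=O)Nc2ccccc2Cl)c2cc(Cl)ccc2O1`, is not yet measured; it differs from compound 1 by chloro in place of hydrogen on an aromatic carbon. Within the data shown here, no measured pair shows this change, so nothing is known of its effect. Compound 3 is expected to stay near compound 1, with a step of a 1.4-fold lower number from compound 1 to compound 3 (0.13 log units; within the scatter) that may well lie within the scatter. The estimate for compound 3 in this assay is 50000 nM, between 15000 nM and 150000 nM.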

Compound 3, half-maximal inhibitory concentration: 17000 nM
For compound 3 the middle estimate is 2.9-fold (0.47 log units) above the measured one; the range from low to high includes it.
By their numbers in this assay, from the lowest: compounds 3 and 2 (each within the scatter of the next); then compound 1.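

Replacing phenyl with 2-chlorophenyl in the urea gives the first measured effect at this part of the series in this assay: the change brings a 4.0-fold lower number from compound 1 to compound 3 (0.60 log units; beyond the scatter) and so moves the number by more than the usual scatter. A single chloro on this ring, ortho to a large group, is therefore enough to strengthen inhibition modestly, though the values stay high. Nothing available bears on the reason for this step.

The compounds shown leave open whether fluoro, methyl or methoxy at the same carbon would act like chloro. They also leave open whether chloro on another carbon of this ring would give a step of similar size.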